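Anilino replacement of the octylamino chain on the shared core

This account rests on a few compounds, and the source may have more. Where it says the series, first, only, none or still open, it means among the compounds named here.

Measured so far: compound 1 `CCCCCCCCNc1nc(SCc2ccc(C(F)(F)F)cc2)nc2ccccc12` gives 12600 nM in a functional assay on MGC-803 cells (Homo sapiens) for cytotoxicity, read by MTT assay, with a stated time of 72 h; on this read-out lower numbers stand for stronger inhibition and higher numbers for weaker inhibition; compound 2 `FC(F)(F)c1ccc(CSc2nc(Nc3ccc(Cl)cc3)c3ccccc3n2)cc1` gives 16800 nM.

Compound 1 holds the lowest of the two numbers, its nearest neighbour being compound 2 with a 1.3-fold higher number from compound 1 to compound 2 (0.12 log units; within the scatter). Compound 3 `COc1ccc(Nc2nc(SCc3ccc(C(F)(F)F)cc3)nc3ccccc23)cc1` differs from compound 1 by 4-methoxyphenyl in place of octyl on a nitrogen on an aromatic ring. Within the data shown here, the one step that bears on this is the one in which another aryl group replaces the same octyl chain, and it stayed within the scatter, a 1.3-fold higher number from compound 1 to compound 2 (0.12 log units; within the scatter). A step of similar size, not beyond the scatter, is therefore expected for a 1.1-fold higher number from compound 1 to compound 3 (0.05 log units; within the scatter). Compound 3 is estimated to give 14000 nM, within 7000 nM to 28000 nM.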

Compound 3, half-maximal inhibitory concentration: 13800 nM
Estimate against measurement, compound 3: 1.0-fold (0.01 log units) above; low and high end bracket the measured number.
By their numbers in this assay, from the lowest: compounds 1, 3 and 2 (each within the scatter of the next).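

In this assay, a second aryl group in place of octyl on this nitrogen again stays within the scatter (a 1.1-fold higher number from compound 1 to compound 3 (0.04 log units; within the scatter)). Methoxy in place of chloro on an aromatic carbon of that aryl group also stays within the scatter (a 1.2-fold lower number from compound 2 to compound 3 (0.09 log units; within the scatter)), so neither change shown separates these compounds. No measurement at hand offers an explanation for this.

On these data alone, whether an amine or a carboxylic acid in place of chloro or methoxy would move the number beyond the scatter remains open. The same holds for a chain longer than octyl on the nitrogen.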